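A small methyl on the second ring of compound 3

The source may hold more compounds than are shown below. What is called first, only, known or untested is meant among the compounds shown, and "the series" means these compounds.

Compound 1, `Cc1cc(OCCn2c([N+](=O)[O-])cnc2C)ccc1Cl`: in a functional assay on MCF7 cells (Homo sapiens) for cytotoxicity, read by MTT assay, with a stated time of 24 h (a lower number here means a stronger inhibitor, a higher number a weaker inhibitor), compound 1 gives 188 ug/mL.
Compound 2, `Cc1ncc([N+](=O)[O-])n1CCOc1cccc([N+](=O)[O-])c1`: in this assay compound 2 gives 71.7 ug/mL.
Compound 3, `Cc1ncc([N+](=O)[O-])n1CCn1ccnc1`: in this assay compound 3 gives 462 ug/mL.

Among these three, compound 3 carries the highest number. Compound 1 stands nearest to it, with a lower value, and compound 2 furthest, with a lower value still; both gaps lie beyond the scatter. Among the measured compounds shown here, none of the three pairs differs in only one place, so no single measured step exists to guide the next move.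

Compound 4, `Cc1nccn1CCn1c([N+](=O)[O-])cnc1C`, is derived from compound 3 by methyl in place of hydrogen on an aromatic carbon. For the measured compounds named here, with no matching precedent among the measured compounds, the exchange of a hydrogen for a methyl is expected to give a step of a 1.2-fold lower number from compound 3 to compound 4 (0.06 log units; within the scatter) that does not go beyond the scatter in either direction. Compound 4 is therefore estimated to give 400 ug/mL in this assay, within a range of 180 ug/mL to 900 ug/mL.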

Compound 4, half-maximal inhibitory concentration: 157 ug/mL
Compound 4: middle estimate off by 2.5-fold (0.41 log units), on the high side; measured number outside the range, below it.
By their numbers in this assay, from the lowest: compound 2; then compounds 4 and 1 (each within the scatter of the next); then compound 3.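

In this assay, methyl in place of hydrogen on an aromatic carbon, between two ring nitrogen atoms, gives a 2.9-fold lower number from compound 3 to compound 4 (0.47 log units; beyond the scatter). This is the only step among the compounds shown that changes a single place, and it shows that adding one carbon at this position of the second ring moves the number beyond the scatter, though modestly. Nothing measured here accounts for the step.

As far as these compounds go, whether an ethyl group, a chlorine or an amine at the same place would move the number further remains open. So does whether the step would hold in cells other than those of this assay.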